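The compounds below may be only part of what the source reports. "The series", "measured", "known", "first", "only" and "open" are said of these compounds alone.

Compound 1 `CCc1nc(-c2cccc(F)c2)c(C(=O)N2CCN(c3cccc(OC)c3)CC2)o1`: 201 nM
Compound 2 `Cc1ccc(N2CCN(C(=O)c3oc(C)nc3-c3ccccc3)CC2)c(C)c1`: 101 nM
Compound 3 `CCc1nc(-c2ccc(F)cc2)c(C(=O)N2CCN(c3cccc(OC)c3)CC2)o1`: 411 nM

In a functional assay on HL-60 cells (Homo sapiens) for inhibition, read by MTT assay, with a stated time of 72 h (a lower number here means a stronger inhibitor, a higher number a weaker inhibitor), compound 2 gives 101 nM, the lowest of the three numbers shown; its gap to compound 1 lies within the scatter, while that to compound 3 lies beyond it. Compound 4 `Cc1nc(-c2ccccc2)c(C(=O)N2CCN(c3cc(Cl)cc(Cl)c3)CC2)o1` departs from compound 2 at the piperazine nitrogen: 3,5-dichlorophenyl in place of 2,4-dimethylphenyl on an amine nitrogen in a ring. Among the measured compounds shown here, the single measured step, a 2.0-fold higher number from compound 1 to compound 3 (0.31 log units; beyond the scatter), concerns the fluorophenyl on the other side of the shared core and does not bear on this exchange, so no comparable step is available. Compound 4 is therefore expected to stay close to compound 2, with no step beyond the scatter in either direction. Compound 4 is estimated at 150 nM, ranging from 50 nM to 450 nM. This expectation corresponds to a 1.5-fold higher number from compound 2 to compound 4 (0.17 log units; within the scatter).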

Compound 4, half-maximal inhibitory concentration: 41.8 nM
For compound 4 the middle estimate is 3.6-fold (0.55 log units) above the measured one; the whole stated range lies above it.
By their numbers in this assay, from the lowest: compound 4; then compounds 2 and 1 (each within the scatter of the next); then compound 3.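

Among the compounds shown here, at the amine nitrogen in a ring, the earlier compounds offered no step, and here this assay responds to the exchange of 2,4-dimethylphenyl for 3,5-dichlorophenyl, with a 2.4-fold lower number from compound 2 to compound 4 (0.38 log units; beyond the scatter). The two groups have the same counts of heavy atoms, aromatic rings and hydrogen-bond donors and acceptors, so the step arises with those counts unchanged. No measurement offered here explains the step. Still open, on these data alone, is whether the step follows the chlorine atoms or their placement on the ring. A 3,5-dimethylphenyl or a 2,4-dichlorophenyl on the same nitrogen would separate the two.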